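The source may hold more compounds than are shown below. What is called first, only, known or untested is meant among the compounds shown, and "the series" means these compounds.

Compound 2 `N#CC1=C(N)Oc2c(c3nc4ccccc4nc3c3ccccc23)C12C(=O)N(Cc1cnnn1-c1ccc(S(N)(=O)=O)cc1)c1ccccc12` stands at a limit in a functional assay on MCF7 cells (Homo sapiens) for antiproliferative activity, read by MTT assay, with a stated time of 48 h (a higher number here means a weaker inhibitor, a lower number a stronger inhibitor), where compound 2 gives > 50000 nM. Compound 1 `N#CC1=C(N)Oc2c(c3nc4ccccc4nc3c3ccccc23)C12C(=O)N(Cc1cnnn1-c1ccc(F)cc1)c1ccccc12` also stands at a limit in this assay, giving > 50000 nM. The step that the two limits leave unreadable from compound 1 to compound 2 thus cannot be read, since both values sit at the limit (the limit of > 50000 nM in this assay, at which 2 of the 2 values shown sit). Compound 3 `Cc1ccc(-n2nncc2CN2C(=O)C3(C(C#N)=C(N)Oc4c3c3nc5ccccc5nc3c3ccccc43)c3ccccc32)cc1C` differs from compound 2 by 3,4-dimethylphenyl in place of 4-sulfamoylphenyl on an aromatic nitrogen. Among the measured compounds shown here, no measured step bears on this change, and the one step available is unreadable. The step expected in this assay is a number no higher from compound 2 to compound 3 (the limit leaves the size open), with no direction that the numbers support. Compound 3 is estimated at 50000 nM, within 10000 nM to 100000 nM.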

Compound 3, half-maximal inhibitory concentration: > 50000 nM
Compound 3 was reported as a limit; the forecaster's own chance of this, stated with the estimate: 75%; the middle value sits exactly at the limit.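

No step among compound 1, compound 2 and compound 3 can be read, since all three sit at the same limit in this assay: the limit of > 50000 nM in this assay, at which 3 of the 3 values shown sit.

The compounds shown leave open whether the group on the aromatic nitrogen has any effect on the read-out in this assay.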